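Extending the chain on the charged core: from compound 3 to compound 4

The source may hold more compounds than are shown below. What is called first, only, known or untested is meant among the compounds shown, and "the series" means these compounds.

Compounds measured so far:
- Compound 1 `CN1/C(=C/C=C/C2=[N+](CCCc3ccccc3)c3ccccc3C2(C)C)C(C)(C)c2ccccc21`: 35%
- Compound 2 `CCCC[N+]1=C(/C=C/C=C2/N(C)c3ccccc3C2(C)C)C(C)(C)c2ccccc21`: 8%
- Compound 3 `CC[N+]1=C(/C=C/C=C2/N(C)c3ccccc3C2(C)C)C(C)(C)c2ccccc21`: "not active" (no number reported)

These three compounds share one core and differ only in the chain attached to the double-bonded nitrogen in a ring. In an assay for displacement of a labelled ligand from protein arginine N-methyltransferase 1 (Homo sapiens), read by scintillation proximity assay, with stated times of 5 min and 8 min, tested at 10 uM (a lower number here means a weaker effect, a higher number a stronger effect of the compound at the concentration tested), compound 1 gives 35%, while compound 2 gives 8%. Among the compounds with values here, the one step between neighbours, a number 27 percentage points lower from compound 1 to compound 2 (beyond the scatter), shows that replacing the phenyl on the chain with a methyl costs a clear part of the effect. Compound 3, with the shortest chain, has no number at all: in this assay compound 3 is recorded as "not active" (no number reported), so it stands at the bottom of this small set without a value to compare.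

Compound 4 `CN1/C(=C/C=C/C2=[N+](CCC[N+](C)(C)C)c3ccccc3C2(C)C)C(C)(C)c2ccccc21` is not yet measured. It differs from compound 3 by a group of 5 heavy atoms (4 carbon, 1 nitrogen; no ring) in place of a hydrogen atom, on a saturated chain carbon, two bonds along the chain from a double-bonded nitrogen in a ring. Within the data shown here, the one measured step bears on it only loosely: it shows that a larger group on the chain, as in compound 1, goes with a stronger effect than a small one, as in compound 2. Compound 4 carries a group of comparable size to that of compound 1, so a rise from compound 3 toward the range of compound 2 and compound 1 is expected in this assay. For compound 4 the estimated value in this assay is 18%, with a range from 0% to 40%.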

Compound 4, a percentage reported as inhibition, at one concentration (the size of the read-out at that concentration, not a potency): 2%
Estimate against measurement, compound 4: 16 percentage points above, and the stated range covers the measured number.
By their numbers in this assay, from the lowest: compounds 4 and 2 (each within the scatter of the next); then compound 1.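

In this assay, placing the group carried by compound 4 where compound 1 has its phenyl gives a number 33 percentage points lower from compound 1 to compound 4 (beyond the scatter), so at this position a sizeable group does not by itself keep the effect. Setting the same group where compound 2 has its methyl gives a number 6 percentage points lower from compound 2 to compound 4 (within the scatter), which means that in this comparison the larger group with net charge +1 cannot be told apart from the methyl. Of the three chains with a number, only the phenyl-bearing chain stands apart, with compound 1 at 35%, which points to the phenyl itself rather than to the count of heavy atoms on the chain.

Nothing available here explains why these chains differ in effect.

As far as these compounds go, it remains open whether a pyridine ring or a cyclohexyl ring on the same chain would hold the effect seen with the phenyl, and whether a longer chain ending in phenyl would raise it. A tertiary amine or a carboxylic acid in place of the phenyl also remains an open case at this position.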